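A few compounds are considered here, and "the series" means these few. Any claim that something is new, unique, unknown or untested is made for them only; others in the source may bear on it.

Measured so far:
- compound 1 `COc1ccc(/C=C/C(=O)c2ccc(N)c(-c3ccc(F)cc3)c2)cc1OC`: > 50000 nM
- compound 2 `COc1ccc(/C=C/C(=O)c2cccc(-c3cccc(F)c3)c2)cc1O`: 9590 nM
- compound 3 `COc1ccc(-c2cc(C(=O)/C=C/c3cc(OC)c(OC)c(OC)c3)ccc2N)cc1OC`: 5440 nM

In an assay on A549 cells for inhibition of transcription factor p65 (Homo sapiens), read by fluorescence, with a stated time of 2 h (a lower number here means a stronger inhibitor, a higher number a weaker inhibitor), compound 3 gives 5440 nM, the lowest of the two numbers shown. The nearest is compound 2 at 9590 nM, a gap within the scatter, so the two are not distinguished. For compound 1 the value > 50000 nM is a limit of the assay, not a number (the limit of > 50000 nM in this assay, at which 1 of the 3 values shown sits).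

The step to compound 4 `COc1cc(/C=C/C(=O)c2ccc(N)c(-c3ccc(F)cc3)c2)cc(OC)c1OC` is 4-fluorophenyl in place of 3,4-dimethoxyphenyl on an aromatic carbon. Within the data shown here, no step between measured compounds isolates this change; the only hint is that compound 1, which also carries the 4-fluorophenyl, sits at a limit. Compound 4 is therefore expected to show a weaker number, a 3.3-fold higher number from compound 3 to compound 4 (0.52 log units; beyond the scatter), beyond the scatter. The estimate for compound 4 is 18000 nM, with a range of 6000 nM to 50000 nM.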

Compound 4, half-maximal inhibitory concentration: 11600 nM
Beside the measured number, compound 4's estimate is 1.6-fold (0.19 log units) above it; the measured number falls inside the stated range.
By their numbers in this assay, from the lowest: compounds 3, 2 and 4 (each within the scatter of the next, the first and the last beyond it). At a limit, above all of these: compound 1.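

In this assay, 4-fluorophenyl in place of 3,4-dimethoxyphenyl, ortho to the amino group, gives a 2.1-fold higher number from compound 3 to compound 4 (0.33 log units; beyond the scatter), so the 3,4-dimethoxyphenyl compound holds a modest edge at this position. Methoxy in place of hydrogen on an aromatic carbon gives an at least 4.3-fold lower number from compound 1 to compound 4 (0.63 log units; beyond the scatter), which shows that the 4-fluorophenyl compounds can also be separated by a change elsewhere. The full size of that step stays open, as compound 1 stands at a limit and not at a number: the limit of > 50000 nM in this assay, at which 1 of the 4 values shown sits.

Open, from the compounds shown here alone, is how a morpholine or a carboxylic acid would read at this position in place of either aryl group. Among these compounds, no step here isolates the amino group itself.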